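A few compounds are considered here, and "the series" means these few. Any claim that something is new, unique, unknown or untested is made for them only; others in the source may bear on it.

Measured compounds:
- compound 1, `CCCCCNC(=O)/N=C(\N)NCCCc1sc(N)nc1C`: 0.78
- compound 2, `Cc1nc(N)sc1CCCN/C(N)=N/C(=O)N[C@@H](C)c1ccccc1`: 1.08
- compound 3, `Cc1nc(N)sc1CCCN/C(N)=N/C(=O)NC(C)c1cccs1`: 0.88

All three share a core and differ only in the group on the amide-type nitrogen. In a functional assay on Right cardiac atrium for agonist activity at histamine H2 receptor (Cavia porcellus), with a stated time of 30 min, in the presence of a further agent that is not named here (on this read-out higher numbers stand for larger maximal responses and lower numbers for smaller maximal responses), compound 2 stands highest; compound 3 is second of the three, close to compound 1 and further from compound 2. The measured steps frame it: a number 0.10 higher from compound 1 to compound 3 (within the scatter), whereas a number 0.20 lower from compound 2 to compound 3 (beyond the scatter), and the larger move a number 0.30 higher from compound 1 to compound 2 (beyond the scatter).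

Compound 4, `Cc1nc(N)sc1CCCN/C(N)=N/C(=O)NCc1ccco1`, is not yet measured. Its change from compound 3 is (furan-2-yl)methyl in place of 1-(thiophen-2-yl)ethyl on an amide-type nitrogen. For the measured compounds named here, no measured step swaps one five-membered aromatic ring for another, and none removes the methyl branch that 1-(thiophen-2-yl)ethyl carries and (furan-2-yl)methyl lacks, so the bearing of the known steps is indirect. They show that the group on this nitrogen shifts the maximal response only modestly, by a few tenths at most, and that a pentyl and an aryl-bearing group sit within scatter of one another.

The estimate for compound 4 is therefore a value near that of compound 3, 0.85, expected within 0.65 to 1.05. The step this implies, a number 0.030 lower from compound 3 to compound 4 (within the scatter), is expected to fall within the scatter.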

Compound 4, intrinsic activity: the largest response reached, as a fraction of the reference agonist's: 0.58
Beside the measured number, compound 4's estimate is 0.27 above it; the measured number lies below the stated range.
By their numbers in this assay, from the lowest: compound 4; then compounds 1 and 3 (each within the scatter of the next); then compound 2.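

In this assay the group on the amide-type nitrogen can pull the maximal response down as well as lift it: the first drop from a ring-bearing group to a smaller one reads a number 0.30 lower from compound 3 to compound 4 (beyond the scatter), and compound 4 is the lowest of the four, with a number 0.50 lower from compound 2 to compound 4 (beyond the scatter) and a number 0.20 lower from compound 1 to compound 4 (beyond the scatter). For the compounds shown here, earlier, no ring-bearing group stood beyond the scatter beneath pentyl, so (furan-2-yl)methyl is the first to do so, and the span at this position is wider than the first three compounds indicated. The change alters the ring hetero atom and removes the methyl branch at once, and no evidence is available that explains the drop or assigns it to either part.

Still open, going by these compounds, is which of the two parts carries the step; 1-(furan-2-yl)ethyl and (thiophen-2-yl)methyl on the same nitrogen would separate them. Also open, on these data alone, is whether benzyl would follow (furan-2-yl)methyl or 1-phenylethyl on this read-out, which would show whether the methyl branch matters with a six-membered ring as well.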